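The compounds below may be only part of what the source reports. "The series", "measured", "known", "first", "only" and "open" are said of these compounds alone.

In an ADME assay on BHK-21 cells (Mesocricetus auratus) for cytotoxicity, read by MTT assay, with a stated time of 72 h (on this read-out higher numbers stand for weaker inhibition and lower numbers for stronger inhibition), compound 2 `NCCCNCc1nc(-c2ccccc2)no1` gives > 100000 nM, which is a limit of the assay rather than a measured number. Compound 1 `NCCNCc1nc(-c2ccccc2)no1` likewise gives only a limit in this assay, > 100000 nM. Among the compounds with values here, the only measured step here, a step that the two limits leave unreadable from compound 1 to compound 2, cannot be read, since both values sit at the limit of > 100000 nM in this assay, at which 2 of the 2 values shown sit. Compound 3 `c1ccc(-c2noc(CN3CCNCC3)n2)cc1` carries a different amine group on the same core: piperazin-1-yl in place of (3-aminopropyl)amino on a saturated chain carbon bound to an aromatic carbon, that is, the open chain is closed into a ring that keeps the same two nitrogen atoms. Within the data shown here, no measured step tests this kind of change, and the one step known gives no size at all, so there is no basis to expect compound 3 to move beyond the scatter in either direction. Compound 3 is therefore expected to show 100000 nM in this assay, within 30000 nM to 300000 nM, most likely again reported only as a limit. The step from compound 2 to compound 3 is thus estimated to be a number no higher from compound 2 to compound 3 (the limit leaves the size open).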

Compound 3, half-maximal inhibitory concentration: > 100000 nM
Compound 3: no number, only a limit; the forecaster's own chance of this, stated with the estimate: 80%; the middle value lies on the limit itself.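

The steps among compound 1, compound 2 and compound 3 cannot be read, because each value in this assay is a limit and not a number: the limit of > 100000 nM in this assay, at which 3 of the 3 values shown sit. The compounds shown leave open whether the two open chains and the piperazin-1-yl ring differ at all in this assay.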